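The source may hold more compounds than are shown below. What is called first, only, known or untested is meant among the compounds shown, and "the series" means these compounds.

In a functional assay on A2780 cells (Homo sapiens) for antiproliferative activity, read by sulforhodamine B assay, with a stated time of 72 h (a lower number here means a stronger inhibitor, a higher number a weaker inhibitor), compound 1 (`Cc1cncc(CNC(=O)Nc2ccc(S(=O)(=O)c3ccccc3)cc2)c1`) gives 144 nM, and compound 2 (`Cc1cncc(CNC(=O)Nc2ccc(S(=O)(=O)N3CCOCC3)cc2)c1`) gives 1100 nM. Compound 3 (`O=C(NCc1ccc(Cl)nc1)Nc1ccc(S(=O)(=O)c2ccccc2)cc1`) yields only a limit, > 2000 nM, and not a number. Compound 4 (`Nc1ncc(CNC(=O)Nc2ccc(S(=O)(=O)c3ccccc3)cc2)cn1`) has 2-aminopyrimidin-5-yl in place of 6-chloropyridin-3-yl on a saturated chain carbon bound to an amide-type nitrogen. The closest evidence is an at least 13-fold higher number from compound 1 to compound 3 (1.14 log units; beyond the scatter), made at this same place, which shows that the group here can shift the result substantially. The other step, a 7.6-fold higher number from compound 1 to compound 2 (0.88 log units; beyond the scatter), was made on the sulfonyl sulfur and bears on it only weakly. Among the compounds with values here, no measured step covers the entering group, so a modest move towards a lower number is expected, estimated as an at least 1.6-fold lower number from compound 3 to compound 4 (0.22 log units; that floor lies within the scatter). For compound 4 the estimate is 1200 nM, with an expected range of 200 nM to 5000 nM.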

Compound 4, half-maximal inhibitory concentration: > 2000 nM
Compound 4 ended at the assay's limit (the forecaster's own chance of this, stated with the estimate: 35%); middle value at least 1.6-fold (0.22 log units) from the limit.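

In this assay compound 4 gives > 2000 nM, a limit and not a number. 2-Aminopyrimidin-5-yl in place of 5-methylpyridin-3-yl gives an at least 13-fold higher number from compound 1 to compound 4 (1.14 log units; beyond the scatter), so a second, quite different group at this place also falls well short of compound 1. The step between compound 3 and compound 4 cannot be read, because both stop at the same limit: the limit of > 2000 nM in this assay, at which 2 of the 4 values shown sit.

From the compounds shown here alone, it remains open whether an unsubstituted pyridin-3-yl or a phenyl at this place would keep the activity of compound 1. Going by these compounds, how weak compound 3 and compound 4 really are also remains open.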